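Swapping the Side Chain on Compound 1

The compounds below may be only part of what the source reports. "The series", "measured", "known", "first", "only" and "open" are said of these compounds alone.

Measured compounds:
Compound 1, `CCS(=O)(=O)NCc1cncc(N2C(=O)c3ccc(Cl)cc3C2(C)C)c1`, gives 92 nM in an assay on cells for inhibition of cytochrome P450 11B2, mitochondrial (Homo sapiens), read by HTRF; a lower number here means a stronger inhibitor, a higher number a weaker inhibitor.
Compound 2, `O=C(Nc1cccnc1)c1ccc(Cl)cc1`, gives 420 nM.
Compound 3, `Cc1cccnc1C(=O)NCc1cncc(N2C(=O)c3ccc(Cl)cc3C2(C)C)c1`, gives 9 nM.

Among the three measured values compound 1 stands second highest: compound 2 lies above it, and compound 3 lies below it by the step of a 10-fold lower number from compound 1 to compound 3 (1.01 log units; beyond the scatter), which is the only measured step that differs in one place. Compound 4, `CC(=O)N1CCN(c2cncc(N3C(=O)c4ccc(Cl)cc4C3(C)C)c2)CC1`, differs from compound 1 as follows: 4-acetylpiperazin-1-yl in place of ((ethylsulfonyl)amino)methyl on an aromatic carbon.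

Among the compounds with values here, only the step from compound 1 to compound 3 bears on this change, and only loosely: it exchanged one group on the amine nitrogen for another and left the methylene link in place, whereas in compound 4 the whole side chain is exchanged for a ring bearing no hydrogen-bond donor. The large gain seen there cannot be carried over to a change of this kind. With no closer comparison available, compound 4 is expected to land near compound 1, the estimated step being a 1.6-fold higher number from compound 1 to compound 4 (0.21 log units; within the scatter). Compound 4 is therefore estimated at 150 nM, within a range from 40 nM to 600 nM.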

Compound 4, half-maximal inhibitory concentration: 9 nM
Estimate against measurement, compound 4: 17-fold (1.22 log units) above; measured number below the stated range.
By their numbers in this assay, from the lowest: compounds 3 and 4 (each within the scatter of the next); then compound 1; then compound 2.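

In this assay, exchanging the entire ((ethylsulfonyl)amino)methyl side chain on this aromatic carbon for 4-acetylpiperazin-1-yl gives a 10-fold lower number from compound 1 to compound 4 (1.01 log units; beyond the scatter) and is therefore a gain beyond the scatter. The earlier change, a 10-fold lower number from compound 1 to compound 3 (1.01 log units; beyond the scatter), kept the methylene link and the hydrogen on the amine nitrogen, whereas compound 4 shows that a low number at this position requires neither, since its side chain has no methylene link and no hydrogen-bond donor. No evidence is available to explain why this exchange lowers the number.

The compounds shown leave open whether the gain follows the piperazine ring or the acetyl group on it. From the compounds shown here alone, how a morpholin-4-yl group or a 4-(ethylsulfonyl)piperazin-1-yl group would read at this position also remains open.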